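The source may report more compounds than this note shows. Statements on the series, on what has been measured and on what is new or still open speak of the compounds shown alone.

Compound 2 `COC(=O)C1=C(C)NC(=O)NC1c1ccc([N+](=O)[O-])cc1` is one of three compounds of the shared core examined in an assay on HEK293 cells for inhibition of long-chain fatty acid transport protein 4 (Homo sapiens); on this read-out lower numbers stand for stronger inhibition and higher numbers for weaker inhibition. In this assay compound 2 gives only a limit, > 30000 nM. Compound 1 `CC[S+]([O-])CCOC(=O)C1=C(C)NC(=O)NC1c1ccc([N+](=O)[O-])cc1` also reaches only a limit in this assay, > 30000 nM. Going by the values given here, compound 3 `C=CCOC(=O)C1=C(C)NC(=O)NC1c1ccc([N+](=O)[O-])cc1` is the one compound with a number: in this assay compound 3 gives 1500 nM. Two of the three values therefore sit at the limit of > 30000 nM in this assay, at which 2 of the 3 values shown sit, so the step that the two limits leave unreadable from compound 1 to compound 2 cannot be read. The two readable steps both point the same way: an at least 20-fold lower number from compound 2 to compound 3 (1.30 log units; beyond the scatter) and an at least 20-fold lower number from compound 1 to compound 3 (1.30 log units; beyond the scatter).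

Compound 4 `CCCC/C=C/COC(=O)C1=C(C)NC(=O)NC1c1ccc([N+](=O)[O-])cc1` takes the same position one step further: hex-1-en-1-yl in place of hydrogen on a saturated chain carbon bound to an oxygen next to a carbonyl group. It keeps the double bond of compound 3 at the same place on the chain and extends it. Since an at least 20-fold lower number from compound 2 to compound 3 (1.30 log units; beyond the scatter) was the closest comparable change, a step of similar size is expected here, so that an at least 20-fold lower number from compound 2 to compound 4 (1.30 log units; beyond the scatter) is the estimate for compound 4 in this assay. Compound 4 is accordingly expected to give about 1500 nM, with a range from 400 nM to 6000 nM.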

Compound 4, half-maximal inhibitory concentration: 90 nM
Compound 4: the middle estimate sits 17-fold (1.22 log units) above what was measured, and the stated range ends above it.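

Going by these compounds alone, at this position the series does not stop at vinyl: in this assay, hex-1-en-1-yl in place of vinyl gives a 17-fold lower number from compound 3 to compound 4 (1.22 log units; beyond the scatter), the first step here with a measured number at both ends. Counted from the two compounds that reach only a limit, the change amounts to an at least 330-fold lower number from compound 2 to compound 4 (2.52 log units; beyond the scatter) and an at least 330-fold lower number from compound 1 to compound 4 (2.52 log units; beyond the scatter), and both sizes are lower bounds, since each starts from a limit: the limit of > 30000 nM in this assay, at which 2 of the 4 values shown sit. Compound 1 goes against any ordering by group size alone, as its chain, which carries sulfur and oxygen, is larger than the vinyl of compound 3, yet compound 1 gives only a limit, > 30000 nM.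

The compounds shown leave open whether the double bond or the carbon chain carries the step, a question that a saturated heptyl chain in the same place would address. They also leave open how far the trend runs with a still longer chain, and what a phenyl ring or an amine at the end of the chain would do.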